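The compounds below may be only part of what the source reports. "The series", "measured", "known", "first", "only" and "open" are said of these compounds alone.

Measured so far:
compound 1 `COCCN1C(N)=NC(N)=NC12CCN(C(=O)C1CC1)CC2` – > 100000 nM
compound 2 `COCCN1C(N)=NC(N)=NC12CCN(C(=O)NC1CCC(C)CC1)CC2` – > 100000 nM

Both readings in an ADME assay on HeLa cells (Homo sapiens) for cytotoxicity, read by microscopy, with a stated time of 6 days (a lower number here means that less compound is tolerated, a higher number that more compound is tolerated), are limits of the assay, not numbers. For compound 1 the value > 100000 nM is a limit. For compound 2 the value > 100000 nM is likewise a limit. For the measured compounds named here, the one step between measured compounds, a step that the two limits leave unreadable from compound 1 to compound 2, is therefore unreadable in size; the pair shares the core of compound 1 and differs only in the group on the carbonyl carbon. Going by the values given here, compound 2 thus stands at the limit, as does the only other value shown, which is what the limit of > 100000 nM in this assay, at which 2 of the 2 values shown sit, records.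

Compound 3 `COCCN1C(N)=NC(N)=NC12CCN(C(=O)Nc1ccc(OC)cc1)CC2` is the next step from compound 2: 4-methoxyphenyl in place of 4-methylcyclohexyl on an amide-type nitrogen. Among the compounds with values here, no measured step bears directly on this change; the only step on record, a step that the two limits leave unreadable from compound 1 to compound 2, is unreadable and concerns the carbonyl carbon rather than the amide-type nitrogen. With nothing read beyond the limit so far, compound 3 is expected to stay there, the step of a number no higher from compound 2 to compound 3 (the limit leaves the size open) being expected to show nothing beyond the scatter. Compound 3 is accordingly estimated at 100000 nM, within 40000 nM to 250000 nM, and is expected most likely to return as a limit once more.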

Compound 3, minimum cytotoxic concentration: > 100000 nM
Compound 3: no number, only a limit (the forecaster's own chance of this, stated with the estimate: 80%); the middle value lies on the limit itself.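

Compound 3, like compound 1 and compound 2, gives only a limit of the assay in this assay, so no step among these compounds can be read: the limit of > 100000 nM in this assay, at which 3 of the 3 values shown sit.

The compounds shown leave open whether any other group on the carbonyl carbon or the amide-type nitrogen would give a readable number in this assay.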